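Chloro in Place of Methyl Beside a Charged Chain End

A few compounds are considered here, and "the series" means these few. Any claim that something is new, unique, unknown or untested is made for them only; others in the source may bear on it.

Compound 1 `Cc1cc(-n2cc(C(=O)Nc3cc(F)cc(F)c3)c(=O)c3ccc(N(C)C)nc32)ccc1OCCCCCCC[N+]12CCN(CC1)CC2` — 20.8%
Compound 2 `CN(C)c1ccc2c(=O)c(C(=O)Nc3cc(F)cc(F)c3)cn(-c3ccc(OCCCCCCC[N+]45CCN(CC4)CC5)c(Cl)c3)c2n1` — 20.5%
Compound 3 `Cc1cc(-n2cc(C(=O)Nc3cc(F)cc(F)c3)c(=O)c3ccc(N(C)C)nc32)ccc1OCCCCCCC[n+]1ccccc1` — 55%

Three measured compounds share one core and were read in an assay on LX2 cells for inhibition of COL1A1 promoter (Homo sapiens), read by a luciferase reporter, with a stated time of 24 h, tested at 50 uM; a lower number here means a weaker effect, a higher number a stronger effect of the compound at the concentration tested. Compound 2 differs from compound 1 only by chloro in place of methyl on an aromatic carbon, and that change made a number 0.3 percentage points lower from compound 1 to compound 2 (within the scatter). Compound 3 differs from compound 1 by a group of 6 heavy atoms (5 carbon, 1 nitrogen; one six-membered aromatic ring with 1 hetero atom) in place of a group of 8 heavy atoms (6 carbon, 2 nitrogen; 2 six-membered non-aromatic rings with 2 hetero atoms each), on a saturated chain carbon, seven bonds along the chain from an oxygen on an aromatic ring, and here the step was a number 34.2 percentage points higher from compound 1 to compound 3 (beyond the scatter). Compound 3 therefore holds the highest number of the three, and its distance to both other compounds lies beyond the scatter.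

Compound 4 `CN(C)c1ccc2c(=O)c(C(=O)Nc3cc(F)cc(F)c3)cn(-c3ccc(OCCCCCCC[n+]4ccccc4)c(Cl)c3)c2n1` has not yet been measured in this assay. It differs from compound 3 by chloro in place of methyl on an aromatic carbon. For the measured compounds named here, this is the same change as that from compound 1 to compound 2, with the place described in the same words, so the pair compound 1 to compound 2 is the only guide to what it may do on the core of compound 3.

Because a number 0.3 percentage points lower from compound 1 to compound 2 (within the scatter) stayed within the scatter, compound 4 is expected to sit close to compound 3, with an expected step of a number 2 percentage points lower from compound 3 to compound 4 (within the scatter). The estimate for compound 4 in this assay is 53%, expected to fall between 40% and 66%. This expectation rests on a single earlier instance of the change, on a core whose chain end differs from that of compound 3, so the range is kept wide.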

Compound 4, a percentage reported as inhibition, at one concentration (the size of the read-out at that concentration, not a potency): 21.4%
Estimate against measurement, compound 4: 31.6 percentage points above, outside the stated range (below it).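

In this assay, chloro in place of methyl on an aromatic carbon gave a number 33.6 percentage points lower from compound 3 to compound 4 (beyond the scatter), so the near-silent result on the core of compound 1 did not carry over to the core of compound 3: the same change on two cores in this assay, a number 0.3 percentage points lower (within the scatter) from compound 1 to compound 2 and a number 33.6 percentage points lower (beyond the scatter) from compound 3 to compound 4, 33.3 percentage points apart, beyond the scatter of two such steps

Seen from the chain end, the same interdependence appears, since the swap that had raised the number so much with methyl present gave only a number 0.9 percentage points higher from compound 2 to compound 4 (within the scatter) with chloro present: the same change on two cores in this assay, a number 34.2 percentage points higher (beyond the scatter) from compound 1 to compound 3 and a number 0.9 percentage points higher (within the scatter) from compound 2 to compound 4, 33.3 percentage points apart, beyond the scatter of two such steps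

For the compounds shown here, these four compounds therefore show that the size of the methyl-to-chloro step depends on the chain end it is paired with, so a step read on one core cannot be assumed on the other, but each core offers only one instance of the change and the numbers give no reason for the gap.

The compounds shown leave open how a fluoro or a methoxy group on the same aromatic carbon would read on either core. As far as these compounds go, it also remains open whether this dependence would hold with a different chain end, such as a trimethylammonium group, or with a shorter chain.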